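Sulfur to Selenium on a Saturated Chain Carbon

The source may report more compounds than this note shows. Statements on the series, on what has been measured and on what is new or still open speak of the compounds shown alone.

In a functional assay on MCF7 cells (Homo sapiens) for cytotoxicity, read by MTT assay, with a stated time of 72 h (on this read-out higher numbers stand for weaker inhibition of growth and lower numbers for stronger inhibition of growth), two compounds have been measured so far. Compound 1 `Cc1noc(C)c1C[Se]C#N` gives 8300 nM. Compound 2 `N#CSCc1ccc(-n2cccc2)cc1` gives 36900 nM, the highest of the two numbers; the nearest is compound 1, whose number sits lower by a gap beyond the usual scatter. Among the compounds with values here, these two compounds differ in more than one place, so no single step links them, and only their two values can be set side by side.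

Compound 3 `N#C[Se]Cc1ccc(-n2cccc2)cc1` has not yet been measured in this assay. It differs from compound 2 in one place: a group of 3 heavy atoms (1 carbon, 1 nitrogen, 1 selenium; no ring) in place of a group of 3 heavy atoms (1 carbon, 1 nitrogen, 1 sulfur; no ring), on a saturated chain carbon bound to an aromatic carbon. Within the data shown here, no measured pair shows this exchange directly, so the size of the step must be expected rather than read off. A downward step beyond the scatter is expected in this assay, because compound 1, which also carries selenium in such a group, gives 8300 nM while the sulfur-bearing compound 2 gives 36900 nM. Compound 3 is therefore expected to give about 12000 nM, within a range from 4000 nM to 36000 nM. This estimate means a downward step of a 3.1-fold lower number from compound 2 to compound 3 (0.49 log units; beyond the scatter) in this assay.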

Compound 3, concentration for total growth inhibition: > 100000 nM
Compound 3: a limit, no number (the forecaster's own chance of this, stated with the estimate: 5%); middle value at least 8.3-fold (0.92 log units) away from the limit.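

Compound 3 gives > 100000 nM in this assay, which is a limit of the assay and not a number. Within the data shown here, this is the first direct reading of selenium in place of sulfur on a saturated chain carbon bound to an aromatic carbon, and on the core shared by these two compounds the exchange gives an at least 2.7-fold higher number from compound 2 to compound 3 (0.43 log units; beyond the scatter), so inhibition of growth becomes weaker by a margin beyond the usual scatter. The direction of this step is therefore settled for this pair, but its full size cannot be read, because the value of compound 3 sits at the end of the measurable range: the limit of > 100000 nM in this assay, at which 1 of the 3 values shown sits.

The compounds shown leave open whether the same exchange runs in the same direction on the core of compound 1, since only one matched pair carries it so far. Also open, as far as these compounds go, is how this position would respond to a group of a different kind on the same saturated chain carbon, such as an amine or a carboxylic acid in place of the cyanosulfanyl group.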